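The source may report more compounds than this note shows. Statements on the series, on what has been measured and on what is new or still open speak of the compounds shown alone.

Working notes on the series. Compound 1 `CCN(C[C@H]1CC[C@H](N)CC1)c1nccc(Nc2cc([C@H]3CCN(C)C3=O)[nH]n2)n1` is the reference; in an assay on isolated protein for inhibition of serine/threonine-protein kinase PAK 1 (Homo sapiens) (a higher number here means a weaker inhibitor, a lower number a stronger inhibitor), compound 1 gives 49 nM, the only number shown. Compound 2 `CN1CC(C)(C)C(c2cc(Nc3ccnc(N(C)C[C@H]4CC[C@H](N)CC4)n3)n[nH]2)C1=O` is the other member; in this assay compound 2 returns > 4500 nM, which is a limit of the assay and not a number (the limit of > 4500 nM in this assay, at which 1 of the 2 values shown sits). For the measured compounds named here, compound 2 differs from compound 1 in more than one place, so its two values show only that compound 1 sits on the measured side and compound 2 on the limit. The step from compound 1 to compound 3 `CN1CC[C@H](c2cc(Nc3ccnc(NC[C@H]4CC[C@H](N)CC4)n3)n[nH]2)C1=O` is a single change: hydrogen in place of ethyl on a nitrogen on an aromatic ring. Going by the values given here, no measured step of this kind exists in the set. A modest weakening is expected, with a 2.4-fold higher number from compound 1 to compound 3 (0.39 log units; beyond the scatter) as the estimated step. Compound 3 is thus expected to give about 120 nM, within 40 nM to 400 nM.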

Compound 3, inhibition constant: 111 nM
Beside the measured number, compound 3's estimate is 1.1-fold (0.03 log units) above it; the measured number falls inside the stated range.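

Hydrogen in place of ethyl on a nitrogen on an aromatic ring gives, in this assay, a 2.3-fold higher number from compound 1 to compound 3 (0.36 log units; beyond the scatter), the first single change in the series that can be read as a step. The ethyl group is thus not needed for a measured value at this position: with hydrogen there, compound 3 still gives 111 nM, a number and not a limit, although on the weaker side of the step. Nothing measured in the set bears on the size of this step.

On these data alone, with only hydrogen and ethyl read at this nitrogen, it remains open where a longer chain such as propyl, a cyclopropyl group or a 2-hydroxyethyl chain would fall. Compound 2, whose > 4500 nM is a limit of the assay and not a number, differs from compound 1 in more than one place and gives no reading of this position.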